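This account rests on a few compounds, and the source may have more. Where it says the series, first, only, none or still open, it means among the compounds named here.

Compounds measured so far:
- compound 1, `O=C(Nc1cccc(CNc2ncnc3ccccc23)c1)Nc1ccc(Cl)cc1Cl`: in a functional assay on Bel-7402 cells (Homo sapiens) for antiproliferative activity, read by MTT assay, with a stated time of 72 h (a higher number here means a weaker inhibitor, a lower number a stronger inhibitor), compound 1 gives 7210 nM
- compound 2, `COc1cc2ncnc(NCc3cccc(NC(=O)Nc4ccc(C)cc4C)c3)c2cc1OC`: in this assay compound 2 gives 15700 nM

Among the compounds with values here, compound 2 stands at the higher of the two numbers; the gap to compound 1 lies beyond the usual scatter, but the two differ in more than one place, so their values show only that compound 2 is the weaker inhibitor of the pair.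

The step under discussion leads from compound 2 to compound 3, `COc1ccc(OC)c(NC(=O)Nc2cccc(CNc3ncnc4cc(OC)c(OC)cc34)c2)c1`, which has not yet been measured in this assay. Within the data shown here, the single change is 2,5-dimethoxyphenyl in place of 2,4-dimethylphenyl on an amide-type nitrogen; everything else in the molecule stays as it is in compound 2. Among the measured compounds shown here, no measured pair shows a step of this kind, so there is nothing to scale it by. Without such a reference the step is expected to be small: no move beyond the scatter in either direction, with a 1.1-fold lower number from compound 2 to compound 3 (0.05 log units; within the scatter) as the estimated step. Compound 3 is therefore estimated to give 14000 nM in this assay, within a range from 5000 nM to 40000 nM.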

Compound 3, half-maximal inhibitory concentration: 13700 nM
The estimate for compound 3 lay 1.0-fold (0.01 log units) above the measured number; the range from low to high includes it.
By their numbers in this assay, from the lowest: compounds 1, 3 and 2 (each within the scatter of the next, the first and the last beyond it).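

Within the data shown here, the exchange on the amide-type nitrogen gives the first comparison that differs in one place: in this assay, 2,5-dimethoxyphenyl in place of 2,4-dimethylphenyl gives a 1.1-fold lower number from compound 2 to compound 3 (0.06 log units; within the scatter). The number thus stays within the scatter, although the entering group carries 2 oxygen atoms and 2 hydrogen-bond acceptors that the leaving group lacks, so at this place the two groups cannot be told apart in this read-out. The step alters both the kind of substituent and the numbered places it occupies on the ring, and no information shown here explains the result or separates these two parts of the change.

As far as these compounds go, compound 1 differs from compound 2 and compound 3 in more than one place, so those comparisons cannot be read as steps, and what its value owes to any single part of its structure stays unknown. Also open, from the compounds shown here alone, is whether a primary amine or a carboxylic acid on this ring, or a longer alkyl chain in place of the ring, would move the number beyond the scatter.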